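This account rests on a few compounds, and the source may have more. Where it says the series, first, only, none or still open, it means among the compounds named here.

Measured so far:
compound 1 `CC1COC2(CCN(c3nc(=O)c4cc(C(F)(F)F)cc([N+](=O)[O-])c4s3)CC2)O1` in a physicochemical assay for solubility, read by HPLC (on this read-out higher numbers stand for higher solubility and lower numbers for lower solubility), gives 0.94 ug/mL
compound 2 `CC(C)(C)C(=O)N1CCN(c2nc(=O)c3cc(C(F)(F)F)cc([N+](=O)[O-])c3s2)CC1` in this assay gives 5.87 ug/mL

Compound 2 stands highest of the two numbers; its nearest neighbour is compound 1, whose number is lower by a margin beyond the usual scatter. Compound 3 `O=C(C1CCCC1)N1CCN(c2nc(=O)c3cc(C(F)(F)F)cc([N+](=O)[O-])c3s2)CC1` is the next compound to be measured. It differs from compound 2 in one place: cyclopentyl in place of tert-butyl on a carbonyl carbon. Among the compounds with values here, no measured pair shows a change of this kind, so the step is expected to be small, downward if anything, and not beyond the scatter: a 1.3-fold lower number from compound 2 to compound 3 (0.12 log units; within the scatter). Compound 3 is therefore expected to give about 4.5 ug/mL, within a range from 1.8 ug/mL to 11 ug/mL.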

Compound 3, solubility: 5.34 ug/mL
For compound 3 the middle estimate is 1.2-fold (0.07 log units) below the measured one, within the range that was stated.
By their numbers in this assay, from the lowest: compound 1; then compounds 3 and 2 (each within the scatter of the next).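

On a carbonyl carbon whose other neighbour is an amide-type nitrogen in a ring, cyclopentyl in place of tert-butyl gives a 1.1-fold lower number from compound 2 to compound 3 (0.04 log units; within the scatter) in this assay. A ring of carbon and an open branched group of carbon therefore give values within the scatter of each other at this position, despite the added heavy atom and the ring. No measurement on hand offers a reason for this result.

Only these two carbon-only groups can be compared at this position, so the step says nothing about groups carrying other atoms. From the compounds shown here alone, what an amine, a carboxylic acid or a longer chain on this carbonyl carbon would give in this assay remains open.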